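Oxazolidinone side chain: amide replaces carbamate-linked methyl ether

The compounds below may be only part of what the source reports. "The series", "measured", "known", "first", "only" and "open" are said of these compounds alone.

Measured compounds:
compound 1, `COC[C@H]1CN(c2ccc(-n3cc(-c4ccccn4)cn3)c(F)c2)C(=O)O1`: 2.18
compound 2, `O=C1O[C@@H](Cn2ccnc2)CN1c1ccc(-n2cc(-c3ccccn3)cn2)c(F)c1`: 1.73
compound 3, `CCC(=O)NC[C@H]1CN(c2ccc(-n3cc(-c4ccccn4)cn3)c(F)c2)C(=O)O1`: 2.2

Three compounds share a core and differ only in the group carried on the saturated chain carbon bound to the saturated ring carbon. In a physicochemical assay for lipophilicity, read by HPLC, measured as octanol-water partition (a higher number here means a more lipophilic compound, a lower number a more polar compound), compound 3 gives 2.2, the highest of the three numbers; the two measured steps that end at it are a number 0.02 log units higher from compound 1 to compound 3 (within the scatter) and a number 0.47 log units higher from compound 2 to compound 3 (beyond the scatter), so compound 3 and compound 1 cannot be ordered, while compound 2 stands clearly lower.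

Compound 4, `CONC(=O)[C@H]1CN(c2ccc(-n3cc(-c4ccccn4)cn3)c(F)c2)C(=O)O1`, has not yet been measured. It departs from compound 3 by methoxycarbamoyl in place of (propanoylamino)methyl on a saturated ring carbon. Among the compounds with values here, no measured step exchanges an amide-bearing chain for a group placed directly on the ring carbon, so the two steps that end at compound 3 bear on it only loosely: they show that swapping groups at that part of the molecule moves this assay by modest amounts at most, as in the steps from compound 1 and from compound 2. The incoming methoxycarbamoyl has one heavy atom fewer and one more hydrogen-bond acceptor than the group that leaves, so a downward step of modest size is expected, a number 0.80 log units lower from compound 3 to compound 4 (beyond the scatter). Compound 4 is therefore estimated at 1.4, within 0.8 to 2.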

Compound 4, partition coefficient: >= 1.58
Compound 4: no number, only a limit (the forecaster's own chance of this, stated with the estimate: 2%); at least 0.18 log units between middle value and limit.
By their numbers in this assay, from the lowest: compound 2; then compounds 1 and 3 (each within the scatter of the next).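

In this assay compound 4 gives >= 1.58, which is a limit and not a number. None of the steps from compound 1, compound 2 or compound 3 to compound 4 can be read. The compounds shown leave open where compound 4 stands among the other three, and how methoxycarbamoyl on a saturated ring carbon compares with their groups.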